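The compounds below may be only part of what the source reports. "The series", "measured", "known", "first", "only" and "open" are said of these compounds alone.

Measured in an ADME assay on Vero cells (Chlorocebus sabaeus) for cytotoxicity, read by resazurin assay, with a stated time of 72 h; a lower number here means a stronger inhibitor, a higher number a weaker inhibitor:
- Compound 1 `COc1ccc(C(=O)CCN2CCN(c3ccc(F)cc3)CC2)cc1`: 55000 nM
- Compound 2 `COc1ccc(C(=O)CCN2CCN(c3ccc([N+](=O)[O-])cc3)CC2)cc1`: 587000 nM

Compound 1 gives 55000 nM, the lower of the two numbers. Among the compounds with values here, the only measured step is an 11-fold higher number from compound 1 to compound 2 (1.03 log units; beyond the scatter), and it is large, with nitro in place of fluoro on an aromatic carbon.

Compound 3 `O=C(CCN1CCN(c2ccc(F)cc2)CC1)c1ccc(OC(F)(F)F)cc1` has not yet been measured. It keeps the fluoro group of compound 1 and changes the methoxy group instead: trifluoromethyl in place of methyl on an oxygen on an aromatic ring. This is trifluoromethyl in place of methyl on an oxygen on an aromatic ring. Within the data shown here, no measured pair covers a change at that oxygen, so an 11-fold higher number from compound 1 to compound 2 (1.03 log units; beyond the scatter) bears on it only loosely, and its size is not carried over. A small step, with no firm direction, is expected instead. The estimate means a 1.4-fold lower number from compound 1 to compound 3 (0.14 log units; within the scatter), which is expected to stay within the scatter. Compound 3 is estimated at 40000 nM, with an expected range of 15000 nM to 120000 nM.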

Compound 3, half-maximal inhibitory concentration: 70300 nM
Compound 3: middle estimate off by 1.8-fold (0.24 log units), on the low side, within the range that was stated.
By their numbers in this assay, from the lowest: compounds 1 and 3 (each within the scatter of the next); then compound 2.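

In this assay, the oxygen on the aromatic ring tolerates trifluoromethyl in place of methyl, with a 1.3-fold higher number from compound 1 to compound 3 (0.11 log units; within the scatter) and so no separation between the two compounds. Within the data shown here, the earlier compounds showed only a change on an aromatic carbon, where nitro in place of fluoro gave an 11-fold higher number from compound 1 to compound 2 (1.03 log units; beyond the scatter) and a large step; this is the first reading at the oxygen, and here methoxy to trifluoromethoxy, with its added fluorine atoms, stays within the scatter. No available evidence explains this result.

On these data alone, whether a longer chain on that oxygen, such as ethyl, or a free hydroxyl group in place of the methoxy group would also stay within the scatter remains open. Also open, as far as these compounds go, is how trifluoromethoxy would read alongside nitro rather than fluoro.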